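A few compounds are considered here, and "the series" means these few. Any claim that something is new, unique, unknown or untested is made for them only; others in the source may bear on it.

Measured compounds:
Compound 1, `CN(C(=O)NC(=O)c1ccc([N+](=O)[O-])cc1)c1nc(C(F)(F)F)c(C(=O)N/N=C/c2cccc(C(F)(F)F)c2)s1`: 4.39 ug/mL
Compound 2, `CN(C(=O)NC(=O)c1ccc([N+](=O)[O-])cc1)c1nc(C(F)(F)F)c(C(=O)N/N=C/c2ccc([N+](=O)[O-])cc2)s1`: 9.24 ug/mL
Compound 3, `CN(C(=O)NC(=O)c1ccccc1F)c1nc(C(F)(F)F)c(C(=O)N/N=C/c2cc(C(F)(F)F)cc(C(F)(F)F)c2)s1`: 6.16 ug/mL

All three were tested in a functional assay on MCF7 cells (Homo sapiens) for inhibition, read by MTT assay, with a stated time of 72 h; on this read-out higher numbers stand for weaker inhibition and lower numbers for stronger inhibition. Compound 1 gives the lowest of the three numbers; compound 3 sits within the scatter of compound 1, while compound 2 lies beyond it, with a 2.1-fold higher number from compound 1 to compound 2 (0.32 log units; beyond the scatter).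

Compound 4, `CN(C(=O)NC(=O)c1ccc(C(F)(F)F)cc1)c1nc(C(F)(F)F)c(C(=O)N/N=C/c2cccc(C(F)(F)F)c2)s1`, has not yet been measured. It differs from compound 1 in one place: trifluoromethyl in place of nitro on an aromatic carbon. Cut one bond further out, the exchange reads (4-nitrophenyl)carbonyl to (4-(trifluoromethyl)phenyl)carbonyl.

Within the data shown here, only one measured step involves the same two groups, the step from compound 1 to compound 2, where 4-nitrophenyl replaced 3-(trifluoromethyl)phenyl on a carbon with a double bond to nitrogen and the number rose modestly. That exchange sits at the other end of the molecule and runs in the opposite direction, so it is a loose guide at best. Compound 3, which differs from compound 1 in more than one place, gives a number within the scatter of compound 1. The step to compound 4 is therefore expected to be small and, if anything, toward a lower number, a 1.3-fold lower number from compound 1 to compound 4 (0.10 log units; within the scatter). Compound 4 is estimated at 3.5 ug/mL, expected between 1.6 ug/mL and 7.5 ug/mL.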

Compound 4, half-maximal inhibitory concentration: 8.95 ug/mL
Compound 4: middle estimate off by 2.6-fold (0.41 log units), on the low side; measured number above the stated range.
By their numbers in this assay, from the lowest: compounds 1, 3, 4 and 2 (each within the scatter of the next, the first and the last beyond it).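

In this assay, the exchange of nitro for trifluoromethyl on the aromatic ring of the (4-nitrophenyl)carbonyl group gives a 2.0-fold higher number from compound 1 to compound 4 (0.31 log units; beyond the scatter), a modest step but one that lies beyond the scatter. Among these compounds, the only single-place step measured earlier was at the other end of the molecule, so this is the first direct reading at this position, and it shows that the number is not indifferent to what sits on this aromatic carbon. Among the compounds shown here, only one exchange has been read here, and it describes this pair alone and sets no trend. No measurement shown explains the gap between the two groups.

The compounds shown leave open what an amine, a carboxylic acid or a plain hydrogen at this same aromatic carbon would do to the number relative to nitro and trifluoromethyl. They also leave open whether the exchange from nitro to trifluoromethyl would give a similar step with 4-nitrophenyl, rather than 3-(trifluoromethyl)phenyl, on the carbon with a double bond to nitrogen.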